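A few compounds are considered here, and "the series" means these few. Any claim that something is new, unique, unknown or untested is made for them only; others in the source may bear on it.

Measured compounds:
Compound 1, `CCCC(Oc1ccc(-n2cc(OC)cn2)cc1)c1ccc(C(=O)NCCC(=O)O)cc1`: in a functional assay on cells for antagonist activity at Glucagon receptor (Homo sapiens), read by cAMP accumulation, in the presence of a further agent that is not named here (on this read-out higher numbers stand for weaker inhibition and lower numbers for stronger inhibition), compound 1 gives > 23000 nM, which is a limit of the assay and not a number.
Compound 2, `CCCC(Nc1ccc(-n2cc(C(F)(F)F)cn2)nc1)c1ccc(C(=O)NCCC(=O)O)cc1`: compound 2 gives 1300 nM.
Compound 3, `O=C(O)CCNC(=O)c1ccc(C(Oc2ccc(-n3cc(C(F)(F)F)cn3)cc2)C2CC2)cc1`: compound 3 gives 15000 nM.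

Of the two numbers recorded, compound 3 stands at the higher one; the nearest is compound 2, whose number sits well below it, beyond the scatter of repeated measurements. For the measured compounds named here, the only other value, that of compound 1, is a limit and gives no number to compare.

Compound 4, `O=C(O)CCNC(=O)c1ccc(C(Oc2ccc(-n3cc(C(F)(F)F)cn3)cc2)C2CCC2)cc1`, has not yet been measured. It differs from compound 3 in one place: cyclobutyl in place of cyclopropyl on a saturated chain carbon bound to an aromatic carbon and an oxygen on an aromatic ring. No measured pair among these compounds shows the effect of such a change, so the expectation rests on the modest size of the change alone. The expected step of no change at the digits printed from compound 3 to compound 4 (within the scatter) is small, within the usual scatter, with no clear direction. Compound 4 is therefore estimated at 15000 nM, with a range from 6000 nM to 40000 nM.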

Compound 4, antagonist equilibrium constant: 3000 nM
The estimate for compound 4 lay 5.0-fold (0.70 log units) above the measured number, and the stated range ends above it.
By their numbers in this assay, from the lowest: compound 2; then compound 4; then compound 3. At a limit, above all of these: compound 1.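

In this assay, the group on a saturated chain carbon bound to an aromatic carbon and an oxygen on an aromatic ring proves to be a place where a small change counts: cyclobutyl in place of cyclopropyl gives a 5.0-fold lower number from compound 3 to compound 4 (0.70 log units; beyond the scatter). This is the first one-place comparison among these compounds, and it shows that the four-membered ring gives the stronger inhibition of the two, though compound 4 remains a weak inhibitor on these numbers. No measurement shown here explains the step.

On these data alone, it remains open whether a larger ring such as cyclopentyl would lower the number further, or whether an open branched group such as isopropyl would do as well as cyclobutyl. Compound 2 differs from compound 4 in more than one place, so what sets their numbers apart also stays unresolved.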